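The compounds below may be only part of what the source reports. "The series", "measured", "known", "first", "only" and "open" are said of these compounds alone.

In a functional assay on LN-229 cells (Homo sapiens) for antiproliferative activity, with a stated time of 72 h (on this read-out higher numbers stand for weaker inhibition and lower numbers for stronger inhibition), compound 1 `Nc1ncnn2c([C@@H]3O[C@H](CO)[C@@H](O)[C@H]3O)cc(-c3ccc(F)cc3)c12` gives 65600 nM and compound 2 `COc1ccc(-c2cc([C@@H]3O[C@H](CO)[C@@H](O)[C@H]3O)n3ncnc(N)c23)cc1` gives 40300 nM, so the two cannot be told apart. Compound 3 `Cc1ccccc1-c1cc([C@@H]2O[C@H](CO)[C@@H](O)[C@H]2O)n2ncnc(N)c12` keeps the shared core but carries 2-methylphenyl in place of 4-methoxyphenyl on an aromatic carbon. Going by the values given here, only one measured step bears on this, methoxy in place of fluoro on an aromatic carbon, and a 1.6-fold lower number from compound 1 to compound 2 (0.21 log units; within the scatter) is a small one. No shift beyond the scatter is therefore expected in this assay, and the estimated change is a 1.1-fold higher number from compound 2 to compound 3 (0.05 log units; within the scatter). For compound 3 the expected value is 45000 nM, with a range of 15000 nM to 130000 nM.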

Compound 3, half-maximal inhibitory concentration: > 100000 nM
Compound 3 ended at the assay's limit; the forecaster's own chance of this, stated with the estimate: 25%; middle value at least 2.2-fold (0.34 log units) away from the limit.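

In this assay, going by these compounds alone, the group on this aromatic carbon of the shared core can shift the read-out: 2-methylphenyl in place of 4-methoxyphenyl gives an at least 2.4-fold higher number from compound 2 to compound 3 (0.39 log units; beyond the scatter), the first step here beyond the scatter. Set against 4-fluorophenyl, 2-methylphenyl gives an at least 1.5-fold higher number from compound 1 to compound 3 (0.18 log units; that floor lies within the scatter), so that comparison stays unresolved. The value of compound 3 is a limit and not a number: the limit of > 100000 nM in this assay, at which 1 of the 3 values shown sits.

The compounds shown leave open whether the methyl group's place on the ring or the absence of methoxy matters more, which 4-methylphenyl could separate. On these data alone, how an amine on this phenyl ring would read also remains open.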